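Fluorine Added to the Core of Compound 1

The compounds below may be only part of what the source reports. "The series", "measured", "known", "first", "only" and "open" are said of these compounds alone.

Measured in an assay on V79 cells for inhibition of cytochrome P450 11B1, mitochondrial (Homo sapiens), read by HTRF, with a stated time of 1 h; on this read-out lower numbers stand for stronger inhibition and higher numbers for weaker inhibition:
compound 1, `c1cncc(-c2nc3ccccc3n2C2CC2)c1`, > 8330 nM
compound 2, `N#Cc1cc2c(cc1F)nc(-c1cncc(F)c1)n2C1CC1`, 225 nM
compound 3, `N#Cc1cc2c(cc1F)nc(-c1cccnc1)n2C1CC1`, 117 nM

The value of compound 1 is a limit of this assay, not a number, (the limit of > 8330 nM in this assay, at which 1 of the 3 values shown sits). Compound 3 and compound 2 differ by fluoro in place of hydrogen on an aromatic carbon; the step is a 1.9-fold higher number from compound 3 to compound 2 (0.28 log units; within the scatter). How the core of compound 1 differs from the shared core of compound 2 and compound 3 is not broken down here. Compound 4 `Fc1cccc2c1nc(-c1cccnc1)n2C1CC1` differs from compound 1 by fluoro in place of hydrogen on an aromatic carbon. This is the same kind of change as between compound 3 and compound 2, but the place differs: there it sits two atoms from the ring nitrogen, meta to a large group; here it sits on a ring of carbon only, ortho to a fused ring and meta to a fused ring. The expected step is an at least 1.3-fold lower number from compound 1 to compound 4 (0.14 log units; that floor lies within the scatter) because the same kind of change gave only a 1.9-fold higher number from compound 3 to compound 2 (0.28 log units; within the scatter). Compound 4 is therefore estimated at 6000 nM, between 1500 nM and 25000 nM, in this assay.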

Compound 4, half-maximal inhibitory concentration: > 8330 nM
Compound 4 ended at the assay's limit; the forecaster's own chance of this, stated with the estimate: 50%; middle value at least 1.3-fold (0.14 log units) from the limit.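

In this assay compound 4 gives > 8330 nM, a limit and not a number. Compound 1 and compound 4 both stand at a limit, so no step between them can be read: the limit of > 8330 nM in this assay, at which 2 of the 4 values shown sit.

On these data alone, whether fluoro in place of hydrogen on the core of compound 1 changes the read-out at all stays open.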